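Methyl in Place of Methoxy: Compound 2 to Compound 4

The compounds below may be only part of what the source reports. "The series", "measured", "known", "first", "only" and "open" are said of these compounds alone.

Of the compounds shown here, three have been measured so far. Compound 1 `Cc1noc2c1N=C(c1ccco1)CC(c1ccccc1)C2C(c1ccccc1)C1c2onc(C)c2N=C(c2ccco2)CC1c1ccccc1` gives 32.7 ug/mL in a functional assay on HeLa cells (Homo sapiens) for cytotoxicity, read by MTT assay, with a stated time of 48 h; on this read-out lower numbers stand for stronger inhibition and higher numbers for weaker inhibition. Compound 3 `Cc1ccc(C2=Nc3c(C)noc3C(C(c3ccccc3)C3c4onc(C)c4N=C(c4ccc(C)cc4)CC3c3ccccc3)C(c3ccccc3)C2)cc1` gives 55.1 ug/mL in this assay. Compound 2 `COc1ccc(C(C2c3onc(C)c3N=C(c3ccccc3)CC2c2ccccc2)C2c3onc(C)c3N=C(c3ccccc3)CC2c2ccccc2)cc1` gives 65.9 ug/mL in this assay, the highest of the three numbers, though its gaps to compound 3 and to compound 1 both lie within the scatter. Compound 4 `Cc1ccc(C(C2c3onc(C)c3N=C(c3ccccc3)CC2c2ccccc2)C2c3onc(C)c3N=C(c3ccccc3)CC2c2ccccc2)cc1` has not yet been measured; it differs from compound 2 by methyl in place of methoxy on an aromatic carbon. For the measured compounds named here, none of the measured compounds isolates this change, so no reference step exists. The step of a 1.2-fold lower number from compound 2 to compound 4 (0.08 log units; within the scatter) is therefore expected to stay within the scatter. Compound 4 is estimated at 55 ug/mL in this assay, with a range from 25 ug/mL to 120 ug/mL.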

Compound 4, half-maximal inhibitory concentration: 38.4 ug/mL
Estimate against measurement, compound 4: 1.4-fold (0.16 log units) above; the range from low to high includes it.
By their numbers in this assay, from the lowest: compounds 1, 4, 3 and 2 (each within the scatter of the next).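

For the compounds shown here, the single step at this position is a 1.7-fold lower number from compound 2 to compound 4 (0.23 log units; within the scatter) in this assay, the only comparison here that isolates one change. Going from 4-methoxyphenyl to 4-methylphenyl, para to a large group, removes an oxygen and its hydrogen-bond acceptor, yet the two compounds cannot be told apart on this read-out. Nothing available offers an explanation for this result.

The compounds shown leave open whether an amine, a carboxylic acid or a longer chain at this position would give a step beyond the scatter. They also leave open whether methyl in place of methoxy behaves the same way on a different core.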